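Extending the Propyl Chain of Compound 3 by One Carbon

The source may hold more compounds than are shown below. What is called first, only, known or untested is meant among the compounds shown, and "the series" means these compounds.

In a functional assay on the whole organism for inhibition, with Rattus norvegicus as the target, at a dose of 0.3 mg/kg by the oral route (a lower number here means a weaker effect, a higher number a stronger effect of the compound at the dose given), compound 3 `CCCc1ccc(-c2cc(C)cc(C(=O)Nc3nn[nH]n3)n2)cc1` gives 19%, the second highest of three numbers. Compound 2 `Nc1ccc(-c2cccc(C(=O)Nc3nn[nH]n3)n2)cc1` gives 11% in this assay, which lies within the scatter of compound 3. Compound 1 `CCCc1ccc(-c2cc(OC)cc(C(=O)Nc3nn[nH]n3)n2)cc1` gives 32% in this assay; the step of a number 13 percentage points lower from compound 1 to compound 3 (beyond the scatter) accompanied methyl in place of methoxy on an aromatic carbon. Compound 4 `CCCCc1ccc(-c2cc(C)cc(C(=O)Nc3nn[nH]n3)n2)cc1` differs from compound 3 by methyl in place of hydrogen on a saturated chain carbon, three bonds along the chain from an aromatic carbon, so propyl becomes butyl. Going by the values given here, no measured step touches this chain, and the single known step, a number 13 percentage points lower from compound 1 to compound 3 (beyond the scatter), concerns another part of the shared core, so nothing here points in either direction. Compound 4 is therefore expected to show no change at the digits printed from compound 3 to compound 4 (within the scatter), a step within the scatter. For compound 4 the estimate in this assay is 19%, ranging from 5% to 35%.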

Compound 4, a percentage reported as inhibition, in the whole organism at one dose (the size of the read-out at that dose, not a potency): 17%
Compound 4: the middle estimate sits 2 percentage points above what was measured, within the range that was stated.
By their numbers in this assay, from the lowest: compounds 2, 4 and 3 (each within the scatter of the next); then compound 1.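

Going by these compounds alone, this is the first look at the propyl chain: in this assay, going from propyl to butyl gives a number 2 percentage points lower from compound 3 to compound 4 (within the scatter). One added methyl, three bonds along the chain from an aromatic carbon, therefore leaves the effect at this dose within the usual scatter, a contrast with the step beyond the scatter seen elsewhere on the shared core. No supporting data bear on why this is so.

On these data alone, a longer chain such as hexyl, or an amine or a carboxylic acid at the chain end, remains open. So does whether butyl would behave the same way on the core of compound 1.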